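Cyclohexyl in place of tert-butyl on the amine nitrogen

A few compounds are considered here, and "the series" means these few. Any claim that something is new, unique, unknown or untested is made for them only; others in the source may bear on it.

In a functional assay on SK-BR-3 cells (Homo sapiens) for antiproliferative activity (a lower number here means a stronger inhibitor, a higher number a weaker inhibitor), compound 3 `CC(C)=CCc1cc(C(=O)Nc2cc3ccc(OCCCNC(C)(C)C)c(C)c3oc2=O)ccc1O` gives 660 nM. Compound 1 `CC(C)=CCc1cc(C(=O)Nc2cc3ccc(OCCC4CCCCN4)c(C)c3oc2=O)ccc1O` gives 640 nM and compound 2 `CC(C)=CCc1cc(C(=O)Nc2cc3ccc(OCCCN(C)C(C)C)c(C)c3oc2=O)ccc1O` gives 570 nM, so compound 3 stands level with both, all three lying within the usual scatter of one another.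

Compound 4 `CC(C)=CCc1cc(C(=O)Nc2cc3ccc(OCCCNC4CCCCC4)c(C)c3oc2=O)ccc1O` carries cyclohexyl in place of tert-butyl on an amine nitrogen whose other neighbour is a saturated chain carbon: cyclohexyl in place of tert-butyl on an amine nitrogen. The measured steps that bear on this change all alter the same amine end of the chain. They are a 1.2-fold higher number from compound 2 to compound 3 (0.06 log units; within the scatter), a 1.0-fold higher number from compound 1 to compound 3 (0.01 log units; within the scatter) and a 1.1-fold lower number from compound 1 to compound 2 (0.05 log units; within the scatter), and each stays within the scatter. Going by the values given here, none of the measured compounds carries cyclohexyl, so the group itself is untested here.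

On the strength of those three small steps, no change beyond the scatter is expected in this assay. The estimated step is a 1.1-fold lower number from compound 3 to compound 4 (0.04 log units; within the scatter). Compound 4 is expected at 600 nM, with an estimated range of 300 nM to 1200 nM.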

Compound 4, half-maximal inhibitory concentration: 660 nM
Compound 4: middle estimate off by 1.1-fold (0.04 log units), on the low side; measured number inside the range.
By their numbers in this assay, from the lowest: compounds 2, 1, 3 and 4 (each within the scatter of the next).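

There is no change at the digits printed from compound 3 to compound 4 (within the scatter) in this assay even though cyclohexyl brings one six-membered non-aromatic ring of carbon only and 6 heavy atoms to the amine nitrogen, where tert-butyl has no ring and 4 heavy atoms. The other two amine ends give the same reading, with a 1.2-fold higher number from compound 2 to compound 4 (0.06 log units; within the scatter) and a 1.0-fold higher number from compound 1 to compound 4 (0.01 log units; within the scatter) as well, so all four compounds stand level with one another. This position on the amine nitrogen therefore now accepts a carbon ring as well as the open branched group, and compound 4 adds this ring outside the nitrogen to the piperidin-2-yl of compound 1.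

From the compounds shown here alone, whether a carboxylic acid or a morpholine at the chain end, or a longer chain, would hold this level stays open. No evidence at hand explains why these amine ends read alike.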